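Swapping One Benzyl Group on a Shared Core

This account rests on a few compounds, and the source may have more. Where it says the series, first, only, none or still open, it means among the compounds named here.

- compound 1 `CC(C)(C)OC(=O)N1CCN(c2c(C(=O)NCc3ccc(F)cc3)nc(Br)c3cccnc23)CC1` gives 3000 nM in cell tests
- compound 2 `COc1cccc(CNC(=O)c2nc(Br)c3cccnc3c2N[C@H]2CC[C@H](N)CC2)c1` gives 6000 nM in cell tests

Both numbers come from a functional assay on SK-BR-3 cells (Homo sapiens) for cytotoxicity, read by MTT assay, with a stated time of 72 h (a higher number here means a weaker inhibitor, a lower number a stronger inhibitor), and lie within the usual scatter of each other, so compound 2 stands level with compound 1 on the numbers shown. Their structures differ in more than one place, so the pair isolates no single change.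

Compound 3 `N[C@H]1CC[C@H](Nc2c(C(=O)NCc3ccc(Cl)cc3Cl)nc(Br)c3cccnc23)CC1` has not yet been measured. It has 2,4-dichlorophenyl in place of 3-methoxyphenyl on a saturated chain carbon bound to an amide-type nitrogen and is otherwise the same as compound 2. Among the measured compounds shown here, no measured pair shows what this swap does, so only a small move toward a lower number is expected, not one beyond the scatter. The expected change is a 1.7-fold lower number from compound 2 to compound 3 (0.23 log units; within the scatter) in this estimate. The estimate for compound 3 is 3500 nM (expected range 1200 nM to 10000 nM).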

Compound 3, half-maximal inhibitory concentration: 6000 nM
Beside the measured number, compound 3's estimate is 1.7-fold (0.23 log units) below it, within the range that was stated.
By their numbers in this assay, from the lowest: compounds 1, 2 and 3 (each within the scatter of the next).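

Putting 2,4-dichlorophenyl in place of 3-methoxyphenyl on a saturated chain carbon bound to an amide-type nitrogen gives no change at the digits printed from compound 2 to compound 3 (within the scatter) in this assay. Among the compounds shown here, this is the first pair here that differs in one place only, so this position now has a direct reading, which compounds 1 and 2 could not provide: two aromatic groups of equal heavy-atom count, one with a hydrogen-bond acceptor and one without, stand level. No separate measurement bears on this result, so the data give no explanation for it.

Going by these compounds, whether a quite different group at this position, such as an unsubstituted phenyl, a pyridine ring or a carboxylic acid, would move the number beyond the scatter remains open. On these data alone, the effect of changes elsewhere on the shared core is also open, since compound 1 differs from compounds 2 and 3 in more than one place.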